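Fused ring in place of ethylphenyl on the aryl oxygen

The compounds below may be only part of what the source reports. "The series", "measured", "known", "first", "only" and "open" are said of these compounds alone.

Of the compounds shown here, three with a shared core have been measured. Compound 1 `CC(C)(C)c1ccccc1Oc1ccc(-c2cccc(C(=O)O)c2)cc1NC(=O)Nc1ccc(OC(F)F)cc1` gives 2600 nM in an assay on HeLa cells for inhibition of Indoleamine 2,3-dioxygenase 1 (Homo sapiens), with a stated time of 20 h; on this read-out higher numbers stand for weaker inhibition and lower numbers for stronger inhibition. Within the data shown here, compound 2 `Cc1ccccc1NC(=O)Nc1cc(-c2cccc(C(=O)O)c2)ccc1Oc1ccccc1C(C)(C)C` gives 1000 nM in this assay, and the step of a 2.6-fold lower number from compound 1 to compound 2 (0.41 log units; beyond the scatter) is the only single change measured so far. Compound 3 `CCc1ccccc1Oc1ccc(-c2ccc(OC)c(C(=O)O)c2)cc1NC(=O)Nc1ccc(C)cc1` gives 540 nM in this assay, the lowest of the three numbers shown; its gap to compound 2 lies within the scatter, while its gap to compound 1 lies beyond it. Compound 4 `COc1ccc(-c2ccc(Oc3cccc4c3CCC4)c(NC(=O)Nc3ccc(C)cc3)c2)cc1C(=O)O` differs from compound 3 by 2,3-dihydro-1H-inden-4-yl in place of 2-ethylphenyl on an oxygen on an aromatic ring. Among the measured compounds shown here, the one measured step, a 2.6-fold lower number from compound 1 to compound 2 (0.41 log units; beyond the scatter), concerns the group on an amide-type nitrogen and says nothing about the group on the oxygen; no measured pair bears on this change. With no guidance from the data, the expected step from compound 3 to compound 4 is one that stays within the scatter, a 1.0-fold higher number from compound 3 to compound 4 (0.01 log units; within the scatter). Compound 4 is therefore expected to give 550 nM in this assay, with a range from 200 nM to 1600 nM.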

Compound 4, half-maximal inhibitory concentration: 280 nM
The estimate for compound 4 lay 2.0-fold (0.29 log units) above the measured number, and the stated range covers the measured number.
By their numbers in this assay, from the lowest: compounds 4, 3 and 2 (each within the scatter of the next, the first and the last beyond it); then compound 1.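

Among these compounds, this is the first measured step at the group on an oxygen on an aromatic ring: in this assay, 2,3-dihydro-1H-inden-4-yl in place of 2-ethylphenyl gives a 1.9-fold lower number from compound 3 to compound 4 (0.29 log units; within the scatter) and so leaves the two compounds indistinguishable on this read-out. The position therefore accepts a five-membered non-aromatic ring in this group, with one more carbon, without a change beyond the scatter. Nothing measured explains why the two groups read alike.

Going by these compounds, it remains open whether an amine or a hydroxyl group on that five-membered ring, or a six-membered non-aromatic ring in its place, would keep the number within the scatter. Also open, on these data alone, is whether the same exchange would read alike in compound 2, which differs from compound 3 in more than one place.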